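The compounds below may be only part of what the source reports. "The series", "measured", "known", "first", "only" and "open" are said of these compounds alone.

Measured so far:
compound 1 `COc1cc(Cl)cc(-c2nn(-c3cccc(NC(=O)Nc4ccc(Cl)c(C(F)(F)F)c4)c3)cc2-c2ccncc2)c1` — 98%
compound 2 `COc1cc(Cl)cc(-c2nn(-c3cccc(NC(=O)c4cccc(C(F)(F)F)c4)c3)cc2-c2ccncc2)c1` — 95%

Both numbers come from a functional assay on CAKI-1 cells (Homo sapiens) for inhibition, read by sulforhodamine B assay, with a stated time of 48 h, tested at 0.01 uM; a higher number here means a weaker effect of the compound at the concentration tested, a lower number a stronger effect. Among the measured compounds shown here, compound 1 stands alongside compound 2, the only other measured compound; the step of a number 3 percentage points lower from compound 1 to compound 2 (within the scatter) keeps the two within the scatter, so neither can be set above the other on these data. That step, 3-(trifluoromethyl)phenyl in place of (4-chloro-3-(trifluoromethyl)phenyl)amino on a carbonyl carbon, changes a different part of the molecule from the one now in question.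

Compound 3 `O=C(Nc1cccc(-n2cc(-c3ccncc3)c(-c3cc(O)cc(Cl)c3)n2)c1)Nc1ccc(Cl)c(C(F)(F)F)c1` is not yet measured. It differs from compound 1 by hydrogen in place of methyl on an oxygen on an aromatic ring: methoxy to hydroxy, 3-chloro-5-methoxyphenyl to 3-chloro-5-hydroxyphenyl, the oxygen sitting on an aromatic ring whose other neighbour is an aromatic carbon. For the measured compounds named here, no measured step touches that oxygen, so there is nothing to scale an expectation from; the one measured step is within the scatter and speaks only for the amide side. The expected step of a number 3 percentage points lower from compound 1 to compound 3 (within the scatter) in this assay is therefore set at nothing beyond the scatter. For compound 3 the estimate is 95%, with a range from 80% to 100%.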

Compound 3, a percentage reported as activity, at one concentration (the size of the read-out at that concentration, not a potency): 102%
Estimate against measurement, compound 3: 7 percentage points below; measured number above the stated range.
By their numbers in this assay, from the lowest: compounds 2, 1 and 3 (each within the scatter of the next).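

In this assay, the change from methoxy to hydroxy on the aromatic ring, 3-chloro-5-methoxyphenyl to 3-chloro-5-hydroxyphenyl, gives a number 4 percentage points higher from compound 1 to compound 3 (within the scatter). Among the compounds shown here, this is the only measured step at this oxygen, and it shows that hydrogen can stand in place of methyl there with the read-out staying within the scatter at this single concentration, so the step gives no ground for setting either compound above the other and says nothing about potency. No available evidence accounts for this result, and the size of the step is all that can be stated.

The compounds shown leave open whether the same change would separate compound 1 and compound 3 at other concentrations, since a reading at one concentration cannot show that. They also leave open whether a longer chain such as ethoxy or propoxy, or an amine in place of the oxygen, would give a step beyond the scatter at this position in this assay.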